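Pyridone nitriles: aryl ether to methylamino switch

The source may hold more compounds than are shown below. What is called first, only, known or untested is meant among the compounds shown, and "the series" means these compounds.

Measured compounds in a functional assay on CHO cells for positive allosteric modulation of metabotropic glutamate receptor 2 (Homo sapiens), read by scintillation counting and GTPgammaS binding, with a stated time of 30 min; a higher number here means that more compound is needed for the effect, a lower number that less compound is needed:
- compound 1 `COc1ccc(-c2ccn(CCC(C)C)c(=O)c2C#N)cc1` gives 1150 nM
- compound 2 `CC(C)CCn1ccc(-c2ccc(Oc3ccncc3)cc2)c(C#N)c1=O` gives 550 nM

Compound 2 holds the lowest number of the two in this assay; the nearest is compound 1, and the step of a 2.1-fold lower number from compound 1 to compound 2 (0.32 log units; beyond the scatter) is the only one measured so far. It shows that replacing a small alkoxy group with the aryl ether lowers the number by a modest margin.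

Compound 3 `CNc1ccc(-c2ccn(CCC(C)C)c(=O)c2C#N)cc1` is not yet measured. The change is methylamino in place of (pyridin-4-yl)oxy on an aromatic carbon. Within the data shown here, the only step that bears on it is the reverse of the ether enlargement, since compound 3 carries a small substituent again, of a size closer to that of compound 1. The entering group differs from the methoxy of compound 1 in bearing a hydrogen-bond donor, a feature without precedent in the series, so the expectation leans on size alone. Compound 3 is therefore expected to land near compound 1, the step of a 2.4-fold higher number from compound 2 to compound 3 (0.37 log units; beyond the scatter) going upward. For compound 3 the estimated value is 1300 nM, with a range from 400 nM to 4000 nM.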

Compound 3, half-maximal effective concentration: 460 nM
Beside the measured number, compound 3's estimate is 2.8-fold (0.45 log units) above it; the measured number falls inside the stated range.
By their numbers in this assay, from the lowest: compounds 3 and 2 (each within the scatter of the next); then compound 1.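

In this assay the step of a 1.2-fold lower number from compound 2 to compound 3 (0.08 log units; within the scatter) shows that methylamino on this aromatic carbon gives a number within the scatter of the much larger (pyridin-4-yl)oxy, so in these compounds the large aryl ether is not needed to reach that level. The step of a 2.5-fold lower number from compound 1 to compound 3 (0.40 log units; beyond the scatter) shows that two small groups at this place can also differ beyond the scatter, which the earlier change from methoxy to the aryl ether could not reveal. No measurement on hand accounts for either step.

The compounds shown leave open whether the amine hydrogen matters, a question that dimethylamino at this carbon would address. They also leave open how an unsubstituted amino group or a longer chain on the nitrogen, such as ethylamino, would compare with methylamino.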